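A few compounds are considered here, and "the series" means these few. Any claim that something is new, unique, unknown or untested is made for them only; others in the source may bear on it.

Three compounds that share one core and differ in a single group on an aromatic ring have been measured in a functional assay on A549 cells (Homo sapiens) for inhibition, read by CCK-8 assay, with a stated time of 72 h, tested at 10 uM; on this read-out lower numbers stand for less inhibition of growth and higher numbers for more inhibition of growth at the one concentration tested. The fluoro member, compound 1 `CN(C)C(=O)c1cc2cnc(Nc3ccc(NC(=O)C4(C(=O)Nc5ccc(F)cc5)CC4)cc3)nc2n1C1CCCC1`, gives 102%. The trifluoromethyl member, compound 2 `CN(C)C(=O)c1cc2cnc(Nc3ccc(NC(=O)C4(C(=O)Nc5ccc(C(F)(F)F)cc5)CC4)cc3)nc2n1C1CCCC1`, gives 87.9%. The hydroxy member, compound 3 `CN(C)C(=O)c1cc2cnc(Nc3ccc(NC(=O)C4(C(=O)Nc5ccc(O)cc5)CC4)cc3)nc2n1C1CCCC1`, gives 94.4%. Compound 3 stands within the scatter of both others: the data show a number 7.6 percentage points lower from compound 1 to compound 3 (within the scatter), and likewise a number 6.5 percentage points higher from compound 2 to compound 3 (within the scatter).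

The next member, compound 4 `CN(C)C(=O)c1cc2cnc(Nc3ccc(NC(=O)C4(C(=O)Nc5ccc(C#N)cc5)CC4)cc3)nc2n1C1CCCC1`, has not yet been measured in this assay. It carries cyano in place of hydroxy on an aromatic carbon, para to a large group: cyano in place of hydroxy on an aromatic carbon.

All three measured steps bear on this change, since each exchanges the group at this same place. Only one lies beyond the scatter, namely a number 14.1 percentage points lower from compound 1 to compound 2 (beyond the scatter), and it is modest. Among the compounds with values here, none of the measured compounds carries cyano, so the data set no direction for this exchange. A step beyond the scatter is therefore not expected, and the number should stay close to those of the series. The estimated result is a number 2.4 percentage points lower from compound 3 to compound 4 (within the scatter). The expected value for compound 4 is 92%, with an estimated range from 80% to 104%.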

Compound 4, percent growth inhibition at one concentration: 95%
Beside the measured number, compound 4's estimate is 3 percentage points below it, within the range that was stated.
By their numbers in this assay, from the lowest: compounds 2, 3, 4 and 1 (each within the scatter of the next, the first and the last beyond it).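

In this assay, within the data shown here, the exchange at this place on the aromatic ring makes no readable difference (a number 0.6 percentage points higher from compound 3 to compound 4 (within the scatter)), although hydroxy has 1 hydrogen-bond donor and cyano has 0 hydrogen-bond donors, so the earlier compounds' open question about cyano now has an answer. Among these compounds, the comparisons with the two other groups read the same way (a number 7.1 percentage points higher from compound 2 to compound 4 (within the scatter); a number 7 percentage points lower from compound 1 to compound 4 (within the scatter)), which places cyano within the scatter of hydroxy, trifluoromethyl and fluoro alike, while the only step beyond the scatter remains the modest one between the last two (a number 14.1 percentage points lower from compound 1 to compound 2 (beyond the scatter)). Nothing available explains why these groups give such close numbers at this place.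

All four numbers come from a single concentration, so the data leave open whether lower concentrations would separate these members, which here cannot be told apart apart from that one pair. They also leave open whether an amine, a carboxylic acid or a longer chain on the same aromatic carbon would stay as close to the series as cyano does.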